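Trimming the amide chain on the pyrazole-bearing core

The source may report more compounds than this note shows. Statements on the series, on what has been measured and on what is new or still open speak of the compounds shown alone.

Measured compounds:
compound 1, `CCC1C(=O)N(C)c2cnc(-n3ccc4cc(C(=O)NCC(C)C)ccc43)nc2N1c1ccn(C)n1`, 5600 nM
compound 2, `CC[C@@H]1C(=O)N(C)c2cnc(-n3ccc4cc(C(=O)NCC(C)C)ccc43)nc2N1C1CCCC1`, 638 nM
compound 3, `CCCNC(=O)c1ccc2c(ccn2-c2ncc3c(n2)N(C2CCCC2)[C@H](CC)C(=O)N3C)c1`, 395 nM

In a functional assay on K562 cells (Homo sapiens) for antiproliferative activity, read by CCK-8 assay, with a stated time of 72 h (a lower number here means a stronger inhibitor of growth, a higher number a weaker inhibitor of growth), compound 1 gives the highest number of the three measured compounds; compound 2 sits nearer to it and compound 3 furthest away, both gaps beyond the scatter. Compound 4, `CCCNC(=O)c1ccc2c(ccn2-c2ncc3c(n2)N(c2ccn(C)n2)C(CC)C(=O)N3C)c1`, has not yet been measured. It differs from compound 1 in one place: hydrogen in place of methyl on a saturated chain carbon bound to two saturated chain carbons.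

For the measured compounds named here, one measured step bears directly on this change, since compounds 2 and 3 differ from each other in the same way on the shared core carrying the cyclopentyl substituent: a 1.6-fold lower number from compound 2 to compound 3 (0.21 log units; within the scatter). That step stayed within the scatter, so on this evidence the change is expected to leave the number for compound 4 close to that of compound 1, with at most a small move toward a lower number: a 1.4-fold lower number from compound 1 to compound 4 (0.15 log units; within the scatter). Compound 4 is therefore estimated at 4000 nM, with a range from 1500 nM to 11000 nM.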

Compound 4, concentration for 50% growth inhibition: 8270 nM
Beside the measured number, compound 4's estimate is 2.1-fold (0.32 log units) below it, within the range that was stated.
By their numbers in this assay, from the lowest: compounds 3 and 2 (each within the scatter of the next); then compounds 1 and 4 (each within the scatter of the next).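

In this assay, going from isobutyl to propyl on the pyrazole-bearing core gives a 1.5-fold higher number from compound 1 to compound 4 (0.17 log units; within the scatter), so this change now has a reading on a second core as well as on the one carrying the cyclopentyl substituent. The two steps carry opposite signs, but neither leaves the scatter and neither does the gap between them, so the two cores give the same answer for the loss of this methyl: the same change on two cores in this assay, a 1.6-fold lower number (0.21 log units; within the scatter) from compound 2 to compound 3 and a 1.5-fold higher number (0.17 log units; within the scatter) from compound 1 to compound 4, 2.4-fold (0.38 log units) apart, within the scatter of two such steps Across these four compounds, then, the methyl on this saturated chain carbon shows no measurable weight in growth inhibition on either core.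

The compounds shown leave open how the amide chain responds to larger changes, such as a longer chain like hexyl. They also leave open what an amine or a carboxylic acid at the end of that chain would do.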